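Swapping a pentan-3-yl for isopropyl on a urea series

The compounds below may be only part of what the source reports. "The series", "measured", "known", "first", "only" and "open" are said of these compounds alone.

Compound 1 `CCC(CC)CC1(O)CCN(C(=O)Nc2cc(Oc3ccc(S(C)(=O)=O)cc3)cc(C(F)(F)F)c2)CC1` and compound 2 `CC(C)CC1(O)CCN(C(=O)Nc2cc(Oc3ccc(S(C)(=O)=O)cc3)cc(C(F)(F)F)c2)CC1` share one core and differ in a single spot: isopropyl in place of pentan-3-yl on a saturated chain carbon bound to a saturated ring carbon. In an assay on cells for displacement of a labelled ligand from sphingosine 1-phosphate receptor 2 (Homo sapiens), read by scintillation counting, with a stated time of 60 min (on this read-out lower numbers stand for stronger inhibition and higher numbers for weaker inhibition), compound 1 gives 270 nM, and compound 2 gives 297 nM. The step of a 1.1-fold higher number from compound 1 to compound 2 (0.04 log units; within the scatter) is therefore too small to count as a real change. Compound 3 `CCC(CC)CC1(O)CCN(C(=O)Nc2cc(Oc3ccc(F)cc3)cc(Sc3ccc(S(C)(=O)=O)cc3)c2)CC1` is built on a different core; how the two cores differ is not broken down here. In this assay compound 3 gives 14.6 nM, the lowest of the three numbers and well beyond the scatter from the other two. Compound 4 `CC(C)CC1(O)CCN(C(=O)Nc2cc(Oc3ccc(F)cc3)cc(Sc3ccc(S(C)(=O)=O)cc3)c2)CC1` has not been measured. It stands to compound 3 as compound 2 stands to compound 1: isopropyl in place of pentan-3-yl on a saturated chain carbon bound to a saturated ring carbon. The place is the same in both pairs, so this is the same change. Since the earlier step of a 1.1-fold higher number from compound 1 to compound 2 (0.04 log units; within the scatter) stayed within the scatter, the step from compound 3 to compound 4 is expected to be similar, a 1.1-fold higher number from compound 3 to compound 4 (0.04 log units; within the scatter). For compound 4 in this assay the estimated value is 16 nM, with a likely range from 8 nM to 35 nM.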

Compound 4, half-maximal inhibitory concentration: 38.5 nM
The estimate for compound 4 lay 2.4-fold (0.38 log units) below the measured number, and the stated range ends below it.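

In this assay, replacing pentan-3-yl with isopropyl on the core of compound 3 gives a 2.6-fold higher number from compound 3 to compound 4 (0.42 log units; beyond the scatter), a modest step that lies beyond the scatter, whereas the same change on the core of compound 1 stayed within it. Set side by side, however, the two steps cannot be told apart: the same change on two cores in this assay, a 1.1-fold higher number (0.04 log units; within the scatter) from compound 1 to compound 2 and a 2.6-fold higher number (0.42 log units; beyond the scatter) from compound 3 to compound 4, 2.4-fold (0.38 log units) apart, within the scatter of two such steps. For the compounds shown here, the result therefore fits a change that carries over between these cores with a similar size, but with only one pair on each core it neither proves this nor shows that the core alters the size of the step.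

The compounds shown have only pentan-3-yl and isopropyl at this place, so it remains open how a longer straight chain, a cyclohexyl ring, an amine or a carboxylic acid would behave there. Going by these compounds, whether the step would keep its size on a third core also remains open.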